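Methyl for fluoro on a biphenyl anilinomethylphenol series

The source may report more compounds than this note shows. Statements on the series, on what has been measured and on what is new or still open speak of the compounds shown alone.

Three compounds share a phenol-bearing benzylamine attached to a biphenyl. Compound 1 `Oc1ccccc1CNc1ccc(-c2ccc(F)cc2)cc1` gives 3860 nM in a functional assay on Jurkat cells (Homo sapiens) for activation, with a stated time of 24 h; a higher number here means that more compound is needed for the effect, a lower number that less compound is needed. Compound 2 `Cc1ccc(-c2ccc(NCc3ccccc3O)cc2)cc1` gives 3790 nM in this assay. Compound 3 `Oc1ccccc1CNc1ccc(-c2ccccc2)c(F)c1` gives 2850 nM in this assay; its number is the lowest of the three, but its gaps to compound 2 and to compound 1 are both within the scatter, so no ranking follows. Compound 2 differs from compound 1 by methyl in place of fluoro on an aromatic carbon, and this change produced a 1.0-fold lower number from compound 1 to compound 2 (0.01 log units; within the scatter). Compound 3 and compound 1 contain the same atoms joined differently; the difference between the two cores is not broken down here.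

Compound 4 `Cc1cc(NCc2ccccc2O)ccc1-c1ccccc1` has not been measured. It differs from compound 3 by methyl in place of fluoro on an aromatic carbon. This is the same kind of change as that from compound 1 to compound 2, but the surroundings differ: in the earlier pair the place is described as para to a large group, whereas here it is ortho to a phenyl group (6 heavy atoms) and meta to a group of 9 heavy atoms. The estimate implies a step of a 1.0-fold higher number from compound 3 to compound 4 (0.01 log units; within the scatter), which is expected to be small because the same change gave a 1.0-fold lower number from compound 1 to compound 2 (0.01 log units; within the scatter). The different surroundings leave some added uncertainty. Compound 4 is therefore estimated at 2900 nM, with an expected range from 1400 nM to 6000 nM.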

Compound 4, half-maximal effective concentration: 8610 nM
Beside the measured number, compound 4's estimate is 3.0-fold (0.47 log units) below it; measured number outside the range, above it.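

In this assay, the exchange of fluoro for methyl on an aromatic carbon gave a 3.0-fold higher number from compound 3 to compound 4 (0.48 log units; beyond the scatter), so at this place, ortho to a phenyl group and meta to a group of 9 heavy atoms, the change moved the number by more than the usual scatter of repeated measurements. The same change therefore did not carry over unchanged from the core of compound 1 to the core of compound 3, and the step seen on one core could not be read across to the other: the same change on two cores in this assay, a 1.0-fold lower number (0.01 log units; within the scatter) from compound 1 to compound 2 and a 3.0-fold higher number (0.48 log units; beyond the scatter) from compound 3 to compound 4, 3.1-fold (0.49 log units) apart, beyond the scatter of two such steps. Among the compounds shown here, this shows only that the step depends on where the change is made in these two pairs; it does not show which difference between the two cores is responsible, and two pairs give no rule for how the change would behave on any further core.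

The compounds shown leave open how other groups at the place occupied by fluoro and methyl in compound 3 and compound 4, such as methoxy, an amine or a carboxylic acid, would compare in this assay. They also leave open whether the step from fluoro to methyl would hold with a substituent on the second phenyl ring or with the phenol hydroxyl replaced by a methoxy group.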